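The source may hold more compounds than are shown below. What is called first, only, known or untested is meant among the compounds shown, and "the series" means these compounds.

Working notes on the series.

The two measured compounds share a core and differ only in the phenoxy terminus. Compound 1 `N[C@@H](COP(=O)(O)OCCCOC(=O)CCc1ccccc1OCc1cccc(Oc2ccc(Cl)cc2)c1)C(=O)O` carries a 4-chlorophenyl group there; in an assay on cells for agonist activity at probable G-protein coupled receptor 34 (Mus musculus), with a stated time of 1 h (a higher number here means a larger maximal response, a lower number a smaller maximal response), compound 1 gives 17.8%. Compound 2 `N[C@@H](COP(=O)(O)OCCCOC(=O)CCc1ccccc1OCc1cccc(Oc2ccc(Cl)c(Cl)c2)c1)C(=O)O` carries a 3,4-dichlorophenyl group; in this assay compound 2 gives 18%. Among the compounds with values here, the single step between them, a number 0.2 percentage points higher from compound 1 to compound 2 (within the scatter), adds one chloro on an aromatic carbon and leaves the maximal response unchanged within the scatter, so compound 2 and compound 1 cannot be told apart on these numbers, and compound 2 sits at the same level as the only other measurement.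

Compound 3 `CC(C)(C)c1cccc(Oc2cccc(COc3ccccc3CCC(=O)OCCCOP(=O)(O)OC[C@H](N)C(=O)O)c2)c1` is the next member. Its change from compound 2 is 3-(tert-butyl)phenyl in place of 3,4-dichlorophenyl on an oxygen on an aromatic ring. Within the data shown here, the only measured step that bears on this terminus is the chloro addition on the same ring, and it was within the scatter; nothing measured speaks to an aromatic substituent without halogen. With no step beyond the scatter seen so far, the expectation is a step of no change at the digits printed from compound 2 to compound 3 (within the scatter), that is, no change beyond the scatter. Compound 3 is therefore estimated at 18% in this assay, with a range from 8% to 32%.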

Compound 3, largest response reached (Emax), in percent of the reference or control that the assay uses: 19.9%
Beside the measured number, compound 3's estimate is 1.9 percentage points below it, and the stated range covers the measured number.
By their numbers in this assay, from the lowest: compounds 1, 2 and 3 (each within the scatter of the next).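

Within the data shown here, the exchange of 3,4-dichlorophenyl for 3-(tert-butyl)phenyl on an oxygen on an aromatic ring (a number 1.9 percentage points higher from compound 2 to compound 3 (within the scatter)) is the first step at this position to remove chlorine altogether, and it leaves the maximal response in this assay at the same level. The exchange of 4-chlorophenyl for the same group (a number 2.1 percentage points higher from compound 1 to compound 3 (within the scatter)) reads the same way, so among compounds 1, 2 and 3 neither chlorine nor the tert-butyl group separates one compound from another. At this position, a terminus built of carbon alone therefore matches the chlorinated ones, although the entering group has 10 heavy atoms against 8 for the 3,4-dichlorophenyl group, and nothing on hand accounts for this flat response.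

It remains open whether an amine or a carboxylic acid on this terminal ring would move the maximal response beyond the scatter, since all three termini shown are chlorine or tert-butyl variants of a phenyl group. Going by these compounds, it is also open whether the shared level depends on the terminus at all or is set by the shared core, which would need a change such as a longer chain in place of the propyl link.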